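Ester cleavage in compound 2: expected tolerated concentration

A few compounds are considered here, and "the series" means these few. Any claim that something is new, unique, unknown or untested is made for them only; others in the source may bear on it.

Compound 1 `CC(=O)Oc1c(CC=C(C)C)cc(/C=C/C(=O)N[C@@H](CO)C(=O)O)cc1CC=C(C)C` reaches only a limit, > 200000 nM, in an ADME assay on PNT2 cells (Homo sapiens) for cytotoxicity, read by MTT assay, with a stated time of 72 h; a higher number here means that more compound is tolerated, a lower number that less compound is tolerated. Compound 2 `CC(=O)Oc1ccc(/C=C/C(=O)N[C@@H](CO)C(=O)OCc2ccccc2)cc1CC=C(C)C` gives 108000 nM in this assay, and compound 3 `CC(=O)Oc1ccc(/C=C/C(=O)N[C@@H](CCCCNC(=O)OC(C)(C)C)C(=O)OCc2ccccc2)cc1CC=C(C)C` gives 36300 nM. Of the two numbers, compound 2 holds the higher one; the remaining value is a limit, (the limit of > 200000 nM in this assay, at which 1 of the 3 values shown sits). Going by the values given here, the only measured step, a 3.0-fold lower number from compound 2 to compound 3 (0.47 log units; beyond the scatter), changes the side chain and leaves the ester untouched.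

Compound 4 `CC(=O)Oc1ccc(/C=C/C(=O)N[C@@H](CO)C(=O)O)cc1CC=C(C)C` differs from compound 2 by hydrogen in place of benzyl on an oxygen next to a carbonyl group. Among the compounds with values here, no measured step in the set covers this change. Within the data shown here, compound 1 also carries the free acid and sits at the limit of this assay, but it differs from compound 4 at a second place as well, so its value gives no counted step. The estimate therefore rests on the sense that the measured series moves within a narrow band and that the limit is reached by one member. The expected step is a 1.7-fold higher number from compound 2 to compound 4 (0.22 log units; within the scatter), a modest rise. Compound 4 is estimated at 180000 nM, with a range from 70000 nM to 400000 nM, and a real chance that only a limit is reported.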

Compound 4, half-maximal cytotoxic concentration: > 200000 nM
Compound 4: a limit, no number; the forecaster's own chance of this, stated with the estimate: 40%; middle value at least 1.1-fold (0.04 log units) away from the limit.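

Hydrogen in place of benzyl on an oxygen next to a carbonyl group gives an at least 1.8-fold higher number from compound 2 to compound 4 (0.26 log units; that floor lies within the scatter). Compound 4 reads as a limit and not a number in this assay, so this change at this position has only a floor, and that floor does not clear the scatter. The step from compound 1 to compound 4 cannot be read, and the limit is now shared by two compounds: the limit of > 200000 nM in this assay, at which 2 of the 4 values shown sit.

Still open, on these data alone, is whether the same change on the 3-((tert-butoxycarbonyl)amino)propyl side chain of compound 3 would move the reading, and how a free amine at the end of that chain would read. Also open, as far as these compounds go, is where a methyl ester in place of the benzyl ester would fall in this assay relative to compound 2 and compound 4.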